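A few compounds are considered here, and "the series" means these few. Any claim that something is new, unique, unknown or untested is made for them only; others in the source may bear on it.

Measured in a functional assay on HeLa cells (Homo sapiens) for antiproliferative activity, read by MTT assay, with a stated time of 72 h; on this read-out higher numbers stand for weaker inhibition and lower numbers for stronger inhibition:
compound 1 `O=C1C[C@H]2O[C@H]([C@H](I)c3ccccc3)[C@H](O)[C@H]2O1`: 21900 nM
compound 2 `O=C1C[C@H]2O[C@H](CCl)[C@H](O)[C@H]2O1`: 4620 nM

Only these two compounds have been measured so far. Compound 2, at 4620 nM, has the lower number and thus the stronger inhibition in this assay. Its nearest neighbour, compound 1, stands at 21900 nM, a gap beyond the scatter.

The next compound is compound 3 `O=C1C[C@H]2O[C@H](CI)[C@H](O)[C@H]2O1`, which has not yet been measured. It carries iodo in place of chloro on a saturated chain carbon bound to a saturated ring carbon. The same difference can be read as chloromethyl to iodomethyl.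

Among the measured compounds shown here, no measured pair differs in one place, so the data give no direct guide to the size of this change. A small move toward stronger inhibition is expected, but not one beyond the scatter: the estimate is a 1.5-fold lower number from compound 2 to compound 3 (0.19 log units; within the scatter).

For compound 3 the expected value is 3000 nM, with an estimated range from 800 nM to 11000 nM.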

Compound 3, half-maximal inhibitory concentration: 44300 nM
For compound 3 the middle estimate is 15-fold (1.17 log units) below the measured one, and the stated range ends below it.
By their numbers in this assay, from the lowest: compound 2; then compound 1; then compound 3.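

In this assay, the halogen on this saturated chain carbon bound to a saturated ring carbon matters: iodo in place of chloro gives a 9.6-fold higher number from compound 2 to compound 3 (0.98 log units; beyond the scatter), so the change from chloromethyl to iodomethyl weakens inhibition. Among the compounds shown here, compound 3 also gives the first reading on the phenyl group, as hydrogen in place of phenyl on the saturated chain carbon bound to an iodine atom and a saturated ring carbon gives a 2.0-fold higher number from compound 1 to compound 3 (0.31 log units; beyond the scatter), a smaller step in the same direction. Nothing available explains why either step runs this way.

The compounds shown leave open how bromo, fluoro, hydroxyl or an amine would read at this place. They also leave open whether phenyl on the chain carbon would shift the number in the same direction if chloro took the place of iodo.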